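Bromo to chloro on the 4-bromophenyl group

The source may hold more compounds than are shown below. What is called first, only, known or untested is meant among the compounds shown, and "the series" means these compounds.

Values measured in a functional assay on MCF7 cells (Homo sapiens) for inhibition, read by MTT assay, with a stated time of 48 h (on this read-out higher numbers stand for weaker inhibition and lower numbers for stronger inhibition), are as follows.

Compound 1 `O=C(C=CNc1cc(-c2ccccc2)nn1-c1ccccc1)c1ccc(Br)cc1` gives 21700 nM
Compound 2 `COc1ccc(-c2ccnc3c2c(-c2ccccc2)nn3-c2ccccc2)cc1` gives 28700 nM

Compound 1 and compound 2 lie within the scatter of each other in this assay and cannot be ranked on these numbers. Going by the values given here, their structures also differ in more than one place, so the pair offers no measured step to scale from.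

The next compound is compound 3 `O=C(C=CNc1cc(-c2ccccc2)nn1-c1ccccc1)c1ccc(Cl)cc1`, still to be measured. The change from compound 1 is chloro in place of bromo on an aromatic carbon and puts chloro in place of bromo on an aromatic carbon, para to a large group. Among the compounds with values here, with no measured step available, the expectation rests on this single exchange alone, and no direction is favoured. The expected 1.1-fold higher number from compound 1 to compound 3 (0.03 log units; within the scatter) stays within the scatter in this assay and is no real change. For compound 3 the estimated value is 23000 nM (expected range 11000 nM to 46000 nM).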

Compound 3, half-maximal inhibitory concentration: 8070 nM
Compound 3: middle estimate off by 2.9-fold (0.45 log units), on the high side; measured number outside the range, below it.
By their numbers in this assay, from the lowest: compound 3; then compounds 1 and 2 (each within the scatter of the next).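

Going by these compounds alone, exchanging one halogen for another on the aromatic carbon para to a large group is not neutral in this assay: going from 4-bromophenyl to 4-chlorophenyl gives a 2.7-fold lower number from compound 1 to compound 3 (0.43 log units; beyond the scatter) and is the only measured step so far. This position therefore responds to the swap of a single heavy atom, with no change in ring, hydrogen-bond donor or acceptor count, or net charge, which compound 1 and compound 2 could not show since they differ in more than one place. No measurement at hand accounts for this step.

From the compounds shown here alone, a single step gives no trend at this position, and how fluoro, methoxy, an amine or a carboxylic acid would read there remains open. Whether the same exchange would give a similar step on a different core is also unknown.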